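Swapping the Furan for a Pyridine on the Sulfonyl

This account rests on a few compounds, and the source may have more. Where it says the series, first, only, none or still open, it means among the compounds named here.

Three compounds share one core and differ only in the aromatic group attached to a sulfonyl sulfur. In a functional assay on the whole organism (strain Jcl:SD) for inhibition, with Rattus norvegicus as the target, with stated times of 3 min and 3 h, at a dose of 1 mg/kg by the intravenous route (a higher number here means more inhibition at the dose given (going by the name of the read-out), a lower number less inhibition), compound 1 `CNCc1cc(-c2cccnc2F)n(S(=O)(=O)c2cccc(OC)c2)c1` gives 92%. Compound 2 `CNCc1cc(-c2cccnc2F)n(S(=O)(=O)c2cccs2)c1` gives 96%, and compound 3 `CNCc1cc(-c2cccnc2F)n(S(=O)(=O)c2ccco2)c1` gives 74%. Compound 3 stands lowest of the three: the step of a number 18 percentage points lower from compound 1 to compound 3 (beyond the scatter) and the step of a number 22 percentage points lower from compound 2 to compound 3 (beyond the scatter) both go down, while the step of a number 4 percentage points higher from compound 1 to compound 2 (within the scatter) is within the scatter.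

Compound 4 `CNCc1cc(-c2cccnc2F)n(S(=O)(=O)c2ccccn2)c1` has not yet been measured. It differs from compound 3 in one place: pyridin-2-yl in place of furan-2-yl on a sulfonyl sulfur. The two measured steps that bear on this change are those that lead into compound 3, and both show that the furan-2-yl group sits below either of the other two aromatic groups tried on the sulfonyl sulfur, by a modest margin each time. A pyridin-2-yl group is a six-membered aromatic ring, as the 3-methoxyphenyl group of compound 1 is, so the expected step of a number 14 percentage points higher from compound 3 to compound 4 (beyond the scatter) is upward, of about the size seen in those two steps. The estimated value for compound 4 in this assay is 88%, with a range from 70% to 98%.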

Compound 4, a percentage reported as inhibition, in the whole organism at one dose (the size of the read-out at that dose, not a potency): 81%
Compound 4: the middle estimate sits 7 percentage points above what was measured; low and high end bracket the measured number.
By their numbers in this assay, from the lowest: compounds 3 and 4 (each within the scatter of the next); then compounds 1 and 2 (each within the scatter of the next).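

In this assay, pyridin-2-yl in place of furan-2-yl on the sulfonyl sulfur gives a number 7 percentage points higher from compound 3 to compound 4 (within the scatter), so this assay does not tell the two groups apart and furan-2-yl no longer stands alone at the low end of the series. Measured against the other two groups, pyridin-2-yl falls short by a modest margin, with a number 11 percentage points lower from compound 1 to compound 4 (beyond the scatter) and a number 15 percentage points lower from compound 2 to compound 4 (beyond the scatter). Ring size alone does not sort this position, since the six-membered rings of compound 1 and compound 4 lie apart, as do the five-membered rings of compound 2 and compound 3, and nothing available here accounts for these differences.

Still open, as far as these compounds go, is whether pyridin-3-yl or pyridin-4-yl would read like pyridin-2-yl, and how a plain phenyl ring would compare with the 3-methoxyphenyl group of compound 1. Also open, from the compounds shown here alone, is whether the sulfonyl sulfur needs an aromatic ring at all, or whether a methyl group or a short propyl chain there would hold the inhibition seen at this single dose.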